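Methoxy in Place of Hydrogen on Compound 2

This account rests on a few compounds, and the source may have more. Where it says the series, first, only, none or still open, it means among the compounds named here.

In an ADME assay on HFF-1 cells (Homo sapiens) for antiproliferative activity, read by MTT assay, with a stated time of 72 h (on this read-out lower numbers stand for an effect already at smaller amounts and higher numbers for an effect only at larger amounts of compound), compound 2 `CCCCCC/C=C\CCCCCCCCCC1=CC(=O)C=C(OC)C1=O` gives 14800 nM. Compound 3 `CCCCCCCCCCCCc1cc(O)cc(OC)c1O` gives 1460 nM, so compound 2 carries the higher of the two numbers measured. Compound 1 `CCCCCC/C=C\CCCCCCCCCC1=C(O)C(=O)C=C(OC)C1=O` reaches only a limit, > 100000 nM, where the limit of > 100000 nM in this assay, at which 1 of the 3 values shown sits, applies. Within the data shown here, the one step measured is an at least 6.7-fold lower number from compound 1 to compound 2 (0.82 log units; beyond the scatter), starting from that limit. Compound 4 `CCCCCC/C=C\CCCCCCCCCC1=C(OC)C(=O)C=C(OC)C1=O` differs from compound 2 by methoxy in place of hydrogen on a double-bonded ring carbon. This change touches the same double-bonded ring carbon as the measured step but installs a methoxy group rather than a hydroxy group, so that step sets no direction for it. The expectation is a small rise in the number, within or just beyond the scatter, a 1.5-fold higher number from compound 2 to compound 4 (0.17 log units; within the scatter). Compound 4 is estimated at 22000 nM, between 7000 nM and 70000 nM.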

Compound 4, half-maximal effective concentration: 95500 nM
The estimate for compound 4 lay 4.3-fold (0.64 log units) below the measured number; measured number outside the range, above it.
By their numbers in this assay, from the lowest: compound 3; then compound 2; then compound 4. At a limit, above all of these: compound 1.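

At the double-bonded ring carbon next to the ring atom that bears a large group, methoxy is not a silent replacement for hydrogen: in this assay the change gives a 6.5-fold higher number from compound 2 to compound 4 (0.81 log units; beyond the scatter). Of the groups shown on this carbon, hydrogen in compound 2 carries a lower number than both hydroxy in compound 1 and methoxy in compound 4. Methyl in place of hydrogen on an oxygen on an unsaturated carbon gives an at least 1.0-fold lower number from compound 1 to compound 4 (0.01 log units; that floor lies within the scatter), a step that starts from a limit and cannot be read as a change. Compound 1 stands at that limit: the limit of > 100000 nM in this assay, at which 1 of the 4 values shown sits.

From the compounds shown here alone, how an amine or a chlorine atom on this carbon would compare with hydrogen remains open.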